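The compounds below may be only part of what the source reports. "The series", "measured", "known", "first", "only" and "open" are said of these compounds alone.

In an assay on HEK293 cells for displacement of a labelled ligand from 5-hydroxytryptamine receptor 6 (Homo sapiens) (on this read-out lower numbers stand for stronger inhibition and higher numbers for weaker inhibition), the measured compounds stand as follows.
Compound 1 `O=S(=O)(c1cccc2nonc12)N1CCOc2c(N3CCNCC3)cc(Cl)cc21`: 0.501 nM.
Compound 2 `O=S(=O)(c1cccc2cccnc12)N1CCOc2c(N3CCNCC3)cc(Cl)cc21`: 0.631 nM.
Compound 3 `Cc1cc(N2CCNCC2)c2c(c1)N(S(=O)(=O)c1ccccc1F)CCO2`: 0.398 nM.

Compound 3 holds the lowest of the three numbers, though its distance to compound 1 and to compound 2 is small in each case. Compound 4 `O=S(=O)(c1ccccc1F)N1CCOc2c(N3CCNCC3)cc(Cl)cc21` differs from compound 3 by chloro in place of methyl on an aromatic carbon. For the measured compounds named here, the only step measured so far, a 1.3-fold higher number from compound 1 to compound 2 (0.10 log units; within the scatter), concerns the group on the sulfonyl sulfur and not the place altered here, so no measured step bears directly on the exchange of methyl for chloro. The three values together cover a narrow range, and compound 4 is expected to stay within it, with a 1.3-fold higher number from compound 3 to compound 4 (0.10 log units; within the scatter) taken as no step beyond the scatter. Compound 4 is thus estimated at 0.5 nM, in the range 0.2 nM to 1.3 nM.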

Compound 4, inhibition constant: 0.398 nM
Compound 4: middle estimate off by 1.3-fold (0.10 log units), on the high side; measured number inside the range.
By their numbers in this assay, from the lowest: compounds 3, 4, 1 and 2 (each within the scatter of the next).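

In this assay, chloro in place of methyl on the aromatic carbon gives no change at the digits printed from compound 3 to compound 4 (within the scatter), the first step measured at this position. With chloro held in place, 2-fluorophenyl on the sulfonyl sulfur gives a 1.6-fold lower number from compound 2 to compound 4 (0.20 log units; within the scatter) and a 1.3-fold lower number from compound 1 to compound 4 (0.10 log units; within the scatter), so these exchanges of the sulfonyl group also stay within the scatter. No evidence is available to explain these results.

The compounds shown leave open whether a group other than methyl or chloro at this position, such as an amine, a carboxylic acid or a longer chain, would move the number beyond the scatter.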